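This account rests on a few compounds, and the source may have more. Where it says the series, first, only, none or still open, it means among the compounds named here.

Working notes on the series. Compound 1 `O=c1ccoc2cc(OCc3cn(Cc4cccc(Br)c4)nn3)ccc12` in an ADME assay on L02 cells (Homo sapiens) for cytotoxicity, read by MTT assay, with a stated time of 48 h (a lower number here means a stronger inhibitor, a higher number a weaker inhibitor), gives > 300000 nM, which is a limit of the assay rather than a number. Compound 2 `O=c1ccoc2cc(OCc3cn(Cc4ccc(Cl)cc4Cl)nn3)ccc12` in this assay gives > 300000 nM, again a limit. Compound 3 `O=c1ccoc2cc(OCc3cn(Cc4cccc([N+](=O)[O-])c4)nn3)ccc12` in this assay gives > 300000 nM, also a limit. Among the measured compounds shown here, compound 3 therefore stands where the whole series so far stands, at the limit of > 300000 nM in this assay, at which 3 of the 3 values shown sit, and no ordering among compounds 1, 2 and 3 can be read from these numbers. The steps a step that the two limits leave unreadable from compound 1 to compound 2, a step that the two limits leave unreadable from compound 1 to compound 3 and a step that the two limits leave unreadable from compound 2 to compound 3 remain unreadable for the same reason.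

Compound 4 `N#Cc1ccc(Cn2cc(COc3ccc4c(=O)ccoc4c3)nn2)cc1` differs from compound 3 by 4-cyanophenyl in place of 3-nitrophenyl on a saturated chain carbon bound to an aromatic nitrogen. For the measured compounds named here, no measured step bears on this change in a readable way, since every step among compounds 1, 2 and 3 ends at the limit. Compound 4 is accordingly expected to stay at the limit as well, with an expected step of a number no higher from compound 3 to compound 4 (the limit leaves the size open) that carries no readable size. The estimate for compound 4 in this assay is 300000 nM, within a range from 150000 nM to 1000000 nM.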

Compound 4, half-maximal inhibitory concentration: > 300000 nM
Compound 4 gave a limit, no number; the forecaster's own chance of this, stated with the estimate: 85%; the middle value sits exactly at the limit.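

Compound 4 in this assay gives > 300000 nM, a limit of the assay. Among the compounds shown here, no step between compound 4 and compound 1, compound 2 or compound 3 can be read, since all sit at the same limit: the limit of > 300000 nM in this assay, at which 4 of the 4 values shown sit. The compounds shown leave open how these four compounds rank in this assay.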